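The source may hold more compounds than are shown below. What is called first, only, known or untested is meant among the compounds shown, and "the series" means these compounds.

Compound 2 `CCC1C(=O)N(O)C(=O)c2ccccc21` gives 250000 nM in an ADME assay on MT4 cells (Homo sapiens) for cytotoxicity, read by MTT assay (on this read-out lower numbers stand for higher toxicity in this test and higher numbers for lower toxicity in this test), the highest of the two numbers measured, while compound 1 `O=C1c2ccccc2C(CCc2ccccc2)C(=O)N1O` gives 30000 nM. Compound 3 `O=C1c2ccccc2C(CCCc2ccccc2)C(=O)N1O` differs from compound 2 by benzyl in place of hydrogen on a saturated chain carbon, two bonds along the chain from a saturated ring carbon. Among the compounds with values here, the only measured step bearing on this change is an 8.3-fold higher number from compound 1 to compound 2 (0.92 log units; beyond the scatter), which runs the other way, the loss of phenyl from the chain having raised the number. Restoring an aromatic ring as benzyl is expected to reverse most of that, so a step of about an 8.3-fold lower number from compound 2 to compound 3 (0.92 log units; beyond the scatter) toward a lower number is expected. For compound 3 the estimate is therefore 30000 nM, ranging from 9000 nM to 90000 nM.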

Compound 3, half-maximal cytotoxic concentration: 5200 nM
The estimate for compound 3 lay 5.8-fold (0.76 log units) above the measured number; the whole stated range lies above it.
By their numbers in this assay, from the lowest: compound 3; then compound 1; then compound 2.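

Benzyl in place of hydrogen on this chain carbon gives a 48-fold lower number from compound 2 to compound 3 (1.68 log units; beyond the scatter) and benzyl in place of phenyl gives a 5.8-fold lower number from compound 1 to compound 3 (0.76 log units; beyond the scatter) in this assay at this position. An aromatic ring on the chain therefore does not alone set the number: across these compounds it falls from hydrogen through phenyl to benzyl, and none goes against that order. Nothing available here accounts for this order. Still open, from the compounds shown here alone, is whether the number keeps falling with a longer chain, and how an amine or a carboxylic acid in place of the chain's phenyl ring would read.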